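Swapping the benzylic-type heteroaryl on the amine side chain

The source may report more compounds than this note shows. Statements on the series, on what has been measured and on what is new or still open speak of the compounds shown alone.

Measured compounds:
- compound 1, `Nc1nc(NCc2cccs2)nc2sc(-c3ccco3)nc12`, 75 nM
- compound 2, `Nc1nc(NCc2ccncc2)nc2sc(-c3ccco3)nc12`, 33 nM

Going by the values given here, in a functional assay on CHO cells for agonist activity at adenosine receptor A2b (Homo sapiens), read by scintillation counting and cAMP accumulation, with a stated time of 150 min, in the presence of a further agent that is not named here (a lower number here means a stronger inhibitor, a higher number a weaker inhibitor), compound 2 gives 33 nM, the lowest of the two numbers at hand; compound 1 sits nearest, and the only measured step, a 2.3-fold lower number from compound 1 to compound 2 (0.36 log units; beyond the scatter), is beyond the scatter. Compound 3, `Nc1nc(NCc2ccco2)nc2sc(-c3ccco3)nc12`, carries the change (furan-2-yl in place of pyridin-4-yl on a saturated chain carbon bound to a nitrogen on an aromatic ring). The new ring is, like the thiophen-2-yl of compound 1, a five-membered aromatic ring with one hetero atom, so the change partly retraces the step from thiophen-2-yl to pyridin-4-yl; that step, a 2.3-fold lower number from compound 1 to compound 2 (0.36 log units; beyond the scatter), was modest. Compound 3 is therefore expected to land between compound 1 and compound 2, most likely with a somewhat higher number than compound 2, a step of about a 1.7-fold higher number from compound 2 to compound 3 (0.22 log units; within the scatter). The estimate for compound 3 in this assay is 55 nM, with a range from 20 nM to 150 nM.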

Compound 3, half-maximal inhibitory concentration: 82 nM
Compound 3: the middle estimate sits 1.5-fold (0.17 log units) below what was measured, within the range that was stated.
By their numbers in this assay, from the lowest: compound 2; then compounds 1 and 3 (each within the scatter of the next).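

Replacing pyridin-4-yl with furan-2-yl in this assay gives a 2.5-fold higher number from compound 2 to compound 3 (0.40 log units; beyond the scatter), so the lower number of the earlier pair does not carry over to this five-membered ring. Replacing thiophen-2-yl with furan-2-yl gives a 1.1-fold higher number from compound 1 to compound 3 (0.04 log units; within the scatter), which means that the two five-membered rings cannot be told apart here, and among these three groups on a saturated chain carbon bound to a nitrogen on an aromatic ring, only pyridin-4-yl stands apart. Nothing available explains this difference.

The compounds shown leave open whether the lower number belongs to pyridin-4-yl in particular or would also appear with pyridin-3-yl, pyridin-2-yl or a plain phenyl ring. They also leave open how a longer chain between the ring and the amine nitrogen would read in this assay.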